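Side chain on the aromatic nitrogen: compound 2 to compound 3

The compounds below may be only part of what the source reports. "The series", "measured", "known", "first", "only" and "open" are said of these compounds alone.

Within the data shown here, compound 2 `N=c1sc2cc(OC(F)(F)F)ccc2n1CC(N)=O` is the one compound of the series with a number in a functional assay on the whole organism with Rattus norvegicus as the target; a higher number here means that more compound is needed for the effect, a lower number that less compound is needed: compound 2 gives 7 mg/kg. Compound 1 `N=c1sc2cc(OC(F)(F)F)ccc2n1Cc1ccccc1` gives only a limit in this assay, > 10 mg/kg. Among the measured compounds shown here, the step between them, an at least 1.4-fold lower number from compound 1 to compound 2 (0.15 log units; that floor lies within the scatter), is the only measured step, and its floor stays inside the scatter; the one relevant observation is the limit of > 10 mg/kg in this assay, at which 1 of the 2 values shown sits. Compound 3 `CSCCn1c(=N)sc2cc(OC(F)(F)F)ccc21` is not yet measured. It differs from compound 2 in one place: (methylsulfanyl)methyl in place of carbamoyl on a saturated chain carbon bound to an aromatic nitrogen. For the measured compounds named here, no measured step covers this kind of exchange at the saturated chain carbon bound to the aromatic nitrogen, and the single measured step is too small to carry over. The expectation for compound 3 in this assay is therefore no step beyond the scatter, no change at the digits printed from compound 2 to compound 3 (within the scatter). Compound 3 is estimated at 7 mg/kg, with a range from 3 mg/kg to 15 mg/kg.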

Compound 3, dose for half-maximal effect: 1 mg/kg
Compound 3: the middle estimate sits 7.0-fold (0.85 log units) above what was measured; measured number outside the range, below it.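

At the saturated chain carbon bound to an aromatic nitrogen, the side chain now makes a difference beyond the scatter in this assay: (methylsulfanyl)methyl in place of carbamoyl gives a 7.0-fold lower number from compound 2 to compound 3 (0.85 log units; beyond the scatter). The entering group carries 0 hydrogen-bond donors, so among the compounds shown, a low dose at this place does not depend on the carbamoyl group and its donor. Against phenyl, the same group gives an at least 10-fold lower number from compound 1 to compound 3 (1.00 log units; beyond the scatter), a floor and not a measured size, as it rests on a limit: the limit of > 10 mg/kg in this assay, at which 1 of the 3 values shown sits.

The compounds shown do not separate the contribution of the sulfur from that of the 2-(methylsulfanyl)ethyl chain as a whole. A butyl chain, a methoxyethyl chain or an amine at this place would be needed to tell these apart.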